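The source may hold more compounds than are shown below. What is called first, only, known or untested is meant among the compounds shown, and "the series" means these compounds.

Measured compounds:
compound 1 `O=C(COc1cccc2ccccc12)N/N=C/c1ccccc1Br` gives 11.4 ug/mL
compound 2 `COc1ccc(/C=N/NC(=O)COc2cccc3ccccc23)cc1OC` gives 14.7 ug/mL
compound 3 `C/C(=N\NC(=O)COc1cccc2ccccc12)c1ccc(O)cc1O` gives 59.9 ug/mL

The three compounds share a core and were tested in an ADME assay on MT4 cells (Homo sapiens) for cytotoxicity, read by MTT assay, with a stated time of 4 days; on this read-out lower numbers stand for higher toxicity in this test and higher numbers for lower toxicity in this test. Compound 1 stands at the lowest of the three numbers; its nearest neighbour is compound 2, whose value lies within the scatter of repeated measurements, so no order between these two can be claimed. Compound 3 stands furthest away, with a number that lies beyond the scatter, so compound 3 is the one of the three that shows the least toxicity in this assay.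

The unmeasured compound 4 `Cc1ccc(/C=N/NC(=O)COc2cccc3ccccc23)cc1` differs from compound 1 in one place: 4-methylphenyl in place of 2-bromophenyl on a carbon with a double bond to nitrogen. Among the measured compounds shown here, no step between two measured compounds covers this kind of change, so the expectation rests only on the spread of the three numbers. Compound 4 is expected to show a small step of a 1.3-fold higher number from compound 1 to compound 4 (0.12 log units; within the scatter), toward a higher number but likely within the scatter. The estimate for compound 4 in this assay is 15 ug/mL, with a range from 7 ug/mL to 35 ug/mL.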

Compound 4, half-maximal cytotoxic concentration: 83.9 ug/mL
Estimate against measurement, compound 4: 5.6-fold (0.75 log units) below; the whole stated range lies below it.
By their numbers in this assay, from the lowest: compounds 1 and 2 (each within the scatter of the next); then compounds 3 and 4 (each within the scatter of the next).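

In this assay the group on a carbon with a double bond to nitrogen clearly matters: 4-methylphenyl in place of 2-bromophenyl gives a 7.4-fold higher number from compound 1 to compound 4 (0.87 log units; beyond the scatter) at this place, the first single change shown for the series. The two groups match in everything counted here, with the same number of heavy atoms, one six-membered aromatic ring of carbon only, no hydrogen-bond donors or acceptors and no net charge, so these counts do not separate them. Nothing measured on these compounds accounts for the size of this step.

The bromine leaves and the methyl enters in one swap, so the compounds shown do not tell which of the two carries the step. Also open, from the compounds shown here alone, is how a plain phenyl group, or a phenyl group bearing an amine or a carboxylic acid, would read at this place.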